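Methyl for bromo on the phenoxy ring of compound 2

The source may hold more compounds than are shown below. What is called first, only, known or untested is meant among the compounds shown, and "the series" means these compounds.

Measured compounds in a functional assay on SMMC-7721 cells (Homo sapiens) for antiproliferative activity, read by MTT assay, with a stated time of 72 h; a lower number here means a stronger inhibitor, a higher number a weaker inhibitor:
Compound 1, `Cc1nn(C)c(Oc2ccc(F)c(F)c2)c1/C=N\CCCCCCOc1cc2oc(=O)cc(C)c2cc1Cl`, gives only a limit, > 25000 nM.
Compound 2, `Cc1nn(C)c(Oc2ccc(Br)cc2)c1/C=N\CCCCCCOc1cc2oc(=O)cc(C)c2cc1Cl`, gives 3090 nM.

For the measured compounds named here, compound 2 thus holds the only number in this assay; the other value, that of compound 1, is a limit rather than a number (the limit of > 25000 nM in this assay, at which 1 of the 2 values shown sits). Going by the values given here, the one measured step is an at least 8.0-fold lower number from compound 1 to compound 2 (0.90 log units; beyond the scatter), so the substituent on this phenoxy ring clearly matters. Compound 3, `Cc1ccc(Oc2c(/C=N\CCCCCCOc3cc4oc(=O)cc(C)c4cc3Cl)c(C)nn2C)cc1`, continues the same series: methyl in place of bromo on an aromatic carbon. Among the compounds with values here, no measured step compares methyl with bromo at this place, so the direction is open; the bromo to difluoro comparison only shows that the ring's substitution can shift the number well beyond the scatter. Compound 3 is expected to be somewhat weaker, a 1.9-fold higher number from compound 2 to compound 3 (0.29 log units; within the scatter). The estimate for compound 3 is 6000 nM, with a range from 1500 nM to 25000 nM.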

Compound 3, half-maximal inhibitory concentration: 18600 nM
The estimate for compound 3 lay 3.1-fold (0.49 log units) below the measured number; the range from low to high includes it.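

In this assay, bromo and methyl are single heavy atoms on the same aromatic carbon, yet exchanging one for the other gives a 6.0-fold higher number from compound 2 to compound 3 (0.78 log units; beyond the scatter), so this position distinguishes between two groups of equal heavy-atom count, and the result favours bromo. The comparison with the 3,4-difluorophenyl compound gives an at least 1.3-fold lower number from compound 1 to compound 3 (0.12 log units; that floor lies within the scatter), so compound 3 cannot be set apart from compound 1, and the methyl compound need not be any better than the difluoro one. Compound 1 gives a limit and not a number: the limit of > 25000 nM in this assay, at which 1 of the 3 values shown sits.

The compounds shown leave open whether chloro, iodo or methoxy at this place would stand nearer to bromo or to methyl. They also leave open whether the preference for bromo would persist with a shorter chain in place of the hexyl linker.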